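The source may hold more compounds than are shown below. What is called first, only, known or untested is meant among the compounds shown, and "the series" means these compounds.

Measured so far:
- compound 1, `O=C(CSc1nc(Nc2ccccc2)c2ccccc2n1)Nc1cccc(Cl)c1`, in a functional assay on MDA-MB-231 cells (Homo sapiens) for inhibition, read by MTT assay, with a stated time of 72 h (a higher number here means a weaker inhibitor, a lower number a stronger inhibitor), compound 1 gives 16500 nM
- compound 2, `C=CC(=O)Nc1cccc(NC(=O)CSc2nc(Nc3ccccc3F)c3ccccc3n2)c1`, in this assay compound 2 gives 18700 nM

Compound 2 sits alongside compound 1: the two values lie within the scatter of each other, so no order between them is claimed.

Compound 3, `C=CC(=O)Nc1cccc(NC(=O)CSc2nc(Nc3cc(OC)c(OC)c(OC)c3)c3ccccc3n2)c1`, has not been measured. It differs from compound 2 in one place: 3,4,5-trimethoxyphenyl in place of 2-fluorophenyl on a nitrogen on an aromatic ring. Among the compounds with values here, no measured pair shows this change, so the size of the step is unknown. The expectation is no step beyond the scatter, a 1.2-fold lower number from compound 2 to compound 3 (0.10 log units; within the scatter). Compound 3 is thus estimated at 15000 nM, with a range from 5000 nM to 45000 nM.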

Compound 3, half-maximal inhibitory concentration: > 50000 nM
Compound 3 was reported as a limit; the forecaster's own chance of this, stated with the estimate: 10%; middle value at least 3.3-fold (0.52 log units) away from the limit.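

This position on the nitrogen on an aromatic ring is not indifferent to the group it carries in this assay: 3,4,5-trimethoxyphenyl in place of 2-fluorophenyl gives an at least 2.6-fold higher number from compound 2 to compound 3 (0.42 log units; beyond the scatter). Within the data shown here, the earlier compounds offered no pair that differed in one place, so this is the first step read. The value of compound 3 is a limit and not a number, so the step has a floor but no known size: the limit of > 50000 nM in this assay, at which 1 of the 3 values shown sits.

Open, from the compounds shown here alone, is whether a single methoxy group on this ring would give a similar step. Going by these compounds, how an amine or a carboxylic acid there would read also remains unknown.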